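The source may report more compounds than this note shows. Statements on the series, on what has been measured and on what is new or still open speak of the compounds shown alone.

compound 1 `O=C([C@H]1CC2CCC1C2)N1CC(c2nc(-c3cccc(F)c3)no2)C1`: 54000000 nM
compound 2 `O=C(c1ccc(F)cc1)N1CC(c2nc(-c3cccc(Cl)c3)no2)C1`: 47000 nM

In a physicochemical assay for solubility, read by HPLC, in phosphate buffer, with a stated time of 4 h (a lower number here means a less soluble compound, a higher number a more soluble compound), compound 2 at 47000 nM holds the lower of the two numbers. The gap between compound 2 and compound 1 lies well beyond the scatter. On the same read-out compound 1 gives 54000000 nM. Compound 3 `O=C(C1CCC(F)(F)CC1)N1CC(c2nc(-c3cccc(Cl)c3)no2)C1` departs from compound 2 by one change: 4,4-difluorocyclohexyl in place of 4-fluorophenyl on a carbonyl carbon in words, 4,4-difluorocyclohexyl in place of 4-fluorophenyl on a carbonyl carbon. Among the measured compounds shown here, no measured step isolates this change. A rise beyond the scatter is expected, resting only on compound 1 at 54000000 nM with its non-aromatic group on the carbonyl carbon, though it differs elsewhere too. The expected move is a 6.4-fold higher number from compound 2 to compound 3 (0.81 log units; beyond the scatter) in size, upward. For compound 3 the estimated value is 300000 nM within an expected range of 50000 nM to 2000000 nM on this read-out.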

Compound 3, solubility: 130000000 nM
Compound 3: middle estimate off by 430-fold (2.64 log units), on the low side, outside the stated range (above it).
By their numbers in this assay, from the lowest: compound 2; then compound 1; then compound 3.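

In this assay, among the compounds shown here, 4,4-difluorocyclohexyl in place of 4-fluorophenyl on a carbonyl carbon gives a 2800-fold higher number from compound 2 to compound 3 (3.44 log units; beyond the scatter), the only step that isolates a single place. This large rise goes with the exchange of a six-membered aromatic ring for a non-aromatic one plus one more fluorine, with the rest of the structure unchanged. Nothing at hand accounts for the size of this step.

Still open, on these data alone, is whether the ring type or the fluorines carry the step; plain cyclohexyl on the same carbonyl carbon would separate them. Also open, as far as these compounds go, is how an amine on that ring would read.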